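A few compounds are considered here, and "the series" means these few. Any claim that something is new, unique, unknown or untested is made for them only; others in the source may bear on it.

Measured values in a functional assay on MCF7 cells (Homo sapiens) for cytotoxicity, read by MTT assay, with a stated time of 24 h; on this read-out higher numbers stand for weaker inhibition and lower numbers for stronger inhibition:

- compound 1 `FC(F)(F)C(F)(F)C(F)(F)C(F)(F)C(F)(F)C(F)(F)C(F)(F)C(F)(F)CCn1cc(COc2ccccc2-c2nc3ccccc3s2)nn1`: 19200 nM
- compound 2 `c1ccc(-n2cc(COc3ccccc3-c3nc4ccccc4s3)nn2)cc1`: 26200 nM
- compound 3 `COc1ccc(-c2nc3cc(F)ccc3s2)cc1OC`: 20200 nM

All three numbers sit in a single band. Compound 2 is within the usual scatter of compound 3 and also within the scatter of compound 1, so nothing on these three numbers separates compound 2 from the other two. Compound 1 and compound 3 are likewise within the scatter of each other. Within the data shown here, no step between two measured compounds that differ in one place is available, so there is no measured single change to lean on.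

Compound 4 `FC(F)(F)c1cccc(-n2cc(COc3ccccc3-c3nc4ccccc4s3)nn2)c1` is the next candidate. Its difference from compound 2 is trifluoromethyl in place of hydrogen on an aromatic carbon. The remainder of the molecule is unchanged. Without a measured step of this kind in the series, the expectation rests on compound 2 alone: in this assay compound 2 gives 26200 nM, and the expected step from it, a 1.1-fold lower number from compound 2 to compound 4 (0.04 log units; within the scatter), is taken as none beyond the scatter. For compound 4 the estimated value in this assay is therefore 24000 nM, with a range from 10000 nM to 55000 nM that is deliberately wide for want of any comparable measured step.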

Compound 4, half-maximal inhibitory concentration: 18900 nM
Compound 4: the middle estimate sits 1.3-fold (0.10 log units) above what was measured; the range from low to high includes it.
By their numbers in this assay, from the lowest: compounds 4, 1, 3 and 2 (each within the scatter of the next).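

The change from phenyl to 3-(trifluoromethyl)phenyl gives the series its first measured step between compounds that differ in one place, and in this assay that step is a 1.4-fold lower number from compound 2 to compound 4 (0.14 log units; within the scatter). At this aromatic carbon, trifluoromethyl therefore leaves the read-out indistinguishable from hydrogen, and the single band formed by the earlier numbers now extends to one more compound, although this is a single substitution at a single position. No measurement on hand explains why this step is so small.

From the compounds shown here alone, whether an amine or a carboxylic acid on the same aromatic carbon, or trifluoromethyl on another carbon of the same ring, would move the number out of this band remains open. With one step and all values within the scatter of one another, it is also unresolved whether any part of the shared core or its substituents governs the read-out, so the series does not yet show a structure-activity trend in either direction.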